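Ethoxymethyl to propyl on a deazapurine thioamide and nitrile pair

This account rests on a few compounds, and the source may have more. Where it says the series, first, only, none or still open, it means among the compounds named here.

Measured so far in a functional assay on KB cells (Homo sapiens) for cytotoxicity; on this read-out lower numbers stand for stronger inhibition and higher numbers for weaker inhibition:
- compound 1 `CCCn1cc(C(=N)S)c2c(N)ncnc21`: 17000 nM
- compound 2 `CCOCn1cc(C(=N)S)c2c(N)ncnc21`: 68000 nM
- compound 3 `CCOCn1cc(C#N)c2c(N)ncnc21`: > 100000 nM (a limit of the assay, not a number)

Compound 2 to compound 1 carries the change ethyl in place of ethoxy on a saturated chain carbon bound to an aromatic nitrogen and gives a 4.0-fold lower number from compound 2 to compound 1 (0.60 log units; beyond the scatter). Compound 2 to compound 3 carries the change a group of 2 heavy atoms (1 carbon, 1 nitrogen; no ring) in place of a group of 3 heavy atoms (1 carbon, 1 nitrogen, 1 sulfur; no ring), on an aromatic carbon and gives an at least 1.4-fold higher number from compound 2 to compound 3 (0.16 log units; that floor lies within the scatter). Compound 3 sits at the limit of the assay in this assay, (the limit of > 100000 nM in this assay, at which 1 of the 3 values shown sits), so its distance from compound 2 is known only as a floor.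

Compound 4 `CCCn1cc(C#N)c2c(N)ncnc21` is not yet measured. It differs from compound 3 by ethyl in place of ethoxy on a saturated chain carbon bound to an aromatic nitrogen, the same change as from compound 2 to compound 1, and the two cores of compound 3 and compound 4 differ from those of compound 2 and compound 1 by the nitrile in place of the thioamide told above. Compound 4 is expected to sit at an at least 2.5-fold lower number from compound 3 to compound 4 (0.39 log units; beyond the scatter) from compound 3, resting on a 4.0-fold lower number from compound 2 to compound 1 (0.60 log units; beyond the scatter), with the reservation that compound 3 is only a limit. Compound 4 is estimated at 40000 nM, within 15000 nM to 150000 nM.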

Compound 4, half-maximal inhibitory concentration: > 100000 nM
Compound 4 gave a limit, no number (the forecaster's own chance of this, stated with the estimate: 30%); middle value at least 2.5-fold (0.39 log units) away from the limit.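

In this assay compound 4 gives > 100000 nM, a limit of the assay. The step from compound 3 cannot be read, so the change from ethoxymethyl to propyl, seen on the thioamide core as a 4.0-fold lower number from compound 2 to compound 1 (0.60 log units; beyond the scatter), is neither confirmed nor refuted on the nitrile core. On the propyl side, nitrile in place of thioamide gives an at least 5.8-fold higher number from compound 1 to compound 4 (0.76 log units; beyond the scatter), which is a readable step beyond the scatter, but whether the swap of thioamide for nitrile is equally large on the two side chains remains unsettled: the same change on two cores in this assay, an at least 1.4-fold higher number (0.16 log units; that floor lies within the scatter) from compound 2 to compound 3 and an at least 5.8-fold higher number (0.76 log units; beyond the scatter) from compound 1 to compound 4; the limit leaves it open whether they differ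

The compounds shown leave open whether any group on the nitrile core brings a value inside the range of the assay, which is what a reading of the side-chain change on that core would need. They also leave open how a longer chain such as butyl, or a primary amide in place of the thioamide, would read in this assay.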